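A Hydroxy-to-Methyl Swap Carried Onto a Second Core

The source may hold more compounds than are shown below. What is called first, only, known or untested is meant among the compounds shown, and "the series" means these compounds.

Compound 1 `CCCn1nc(C)c2c(C)cc(=O)oc21` gives 54.3 mg/kg in a functional assay on the whole organism with Mus musculus as the target, in the writhing test; on this read-out lower numbers stand for an effect already at smaller amounts and higher numbers for an effect only at larger amounts of compound.
Compound 2 `Cc1cc(=O)oc2c1c(C)nn2CCO` gives 100 mg/kg in this assay.
Compound 3 `Cc1cc(=O)oc2nn(CCO)c(C)c12` shows only a limit of this assay, > 100 mg/kg.

Compound 1 and compound 2 share one core and differ by methyl in place of hydroxy on a saturated chain carbon, two bonds along the chain from an aromatic nitrogen, a change that gave a 1.8-fold lower number from compound 2 to compound 1 (0.27 log units; within the scatter). Compound 3 carries the same hydroxy-bearing chain on a core built from the same atoms joined differently; the difference between the two cores is not broken down here. Compound 3 itself sits at the limit of > 100 mg/kg in this assay, at which 1 of the 3 values shown sits. Compound 4 `CCCn1nc2oc(=O)cc(C)c2c1C` remains unmeasured and differs from compound 3 by methyl in place of hydroxy on a saturated chain carbon, two bonds along the chain from an aromatic nitrogen, the same change seen between compound 2 and compound 1. Because that earlier pair gave a 1.8-fold lower number from compound 2 to compound 1 (0.27 log units; within the scatter), a step of about an at least 1.1-fold lower number from compound 3 to compound 4 (0.04 log units; that floor lies within the scatter) is expected here too. Compound 4 is therefore estimated at 90 mg/kg, with values from 40 mg/kg to 300 mg/kg expected.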

Compound 4, dose for half-maximal effect: 72.6 mg/kg
Compound 4: the middle estimate sits 1.2-fold (0.09 log units) above what was measured, within the range that was stated.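

On the second core, the change from 2-hydroxyethyl to propyl gives an at least 1.3-fold lower number from compound 3 to compound 4 (0.13 log units; that floor lies within the scatter) in this assay. Set beside the step on the first core, the comparison goes only this far: the same change on two cores in this assay, a 1.8-fold lower number (0.27 log units; within the scatter) from compound 2 to compound 1 and an at least 1.3-fold lower number (0.13 log units; that floor lies within the scatter) from compound 3 to compound 4; the limit leaves it open whether they differ. Neither step can be read as lying beyond the usual scatter, so the swap is not firmly shown to lower the number on either core, and its true size on the second core remains unsettled.

The compounds shown leave open how an amine, a carboxylic acid or a longer chain would behave in place of these two chain ends. They also leave open whether the choice of core itself matters in this assay.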